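A Five-Membered Ring Swap on the Saturated Ring Carbon

The source may hold more compounds than are shown below. What is called first, only, known or untested is meant among the compounds shown, and "the series" means these compounds.

Compound 2, `CS(=O)(=O)Nc1cccc2c1CCCC2C1=NCCN1`: 4270 nM
Compound 1, `CCS(=O)(=O)Nc1cccc2c1CCCC2(O)c1c[nH]cn1`: < 10000 nM

Among the measured compounds shown here, in an assay on isolated protein for binding affinity to Alpha-1D adrenergic receptor (Rattus norvegicus), read by radioligand binding (a higher number here means a weaker inhibitor, a lower number a stronger inhibitor), compound 2 gives 4270 nM, the only outright number among the values shown. Compound 1 gives only a limit of the assay, < 10000 nM. That limit is described by the limit of < 10000 nM in this assay, at which 1 of the 2 values shown sits, so the two measured compounds cannot be set in order against each other.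

Compound 3 `Cn1cncc1C1CCCc2c(NS(C)(=O)=O)cccc21` differs from compound 2 by a group of 6 heavy atoms (4 carbon, 2 nitrogen; one five-membered aromatic ring with 2 hetero atoms) in place of a group of 5 heavy atoms (3 carbon, 2 nitrogen; one five-membered non-aromatic ring with 2 hetero atoms), on a saturated ring carbon. For the measured compounds named here, no step between measured compounds is known, so the effect of this change has to be judged from the two values alone. A step beyond the usual scatter, toward weaker binding, is expected: the estimated step is a 3.5-fold higher number from compound 2 to compound 3 (0.55 log units; beyond the scatter), and there is a fair chance that this assay will report only a limit for compound 3. Compound 3 is therefore expected to give 15000 nM, with a range from 3000 nM to 60000 nM.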

Compound 3, inhibition constant: < 10000 nM
Compound 3: a limit, no number; the forecaster's own chance of this, stated with the estimate: 50%; middle value at least 1.5-fold (0.17 log units) away from the limit.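

In this assay compound 3 gives only a limit of the assay, < 10000 nM, so no new step can be read from compound 2 to compound 3. The compounds shown leave open whether the 1-methyl-1H-imidazol-5-yl group binds more weakly or more strongly than the group it replaces.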